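This account rests on a few compounds, and the source may have more. Where it says the series, first, only, none or still open, it means among the compounds named here.

Measured in a functional assay on HepG2 cells (Homo sapiens) for inhibition, read by MTT assay, with a stated time of 72 h; on this read-out higher numbers stand for weaker inhibition and lower numbers for stronger inhibition:
compound 1 `CC(C)n1ncc2c(C(=O)Nc3ccccc3)cccc21` gives 23700 nM.
compound 2 `CC(C)n1ncc2c(C(=O)Nc3cccnc3)cccc21` gives > 40000 nM, a limit of the assay.
compound 3 `CC(C)n1ncc2c(C(=O)NC3CCCC3)cccc21` gives > 40000 nM, a limit of the assay.

Compound 3 therefore stands at the limit of > 40000 nM in this assay, at which 2 of the 3 values shown sit, and carries no number of its own; only compound 1 gives one. Compound 4 `CC(C)n1ncc2c(C(=O)NCc3ccccc3)cccc21` differs from compound 3 by benzyl in place of cyclopentyl on an amide-type nitrogen. The measured steps that bear on this are an at least 1.6-fold higher number from compound 1 to compound 3 (0.22 log units; that floor lies within the scatter) and an at least 1.6-fold higher number from compound 1 to compound 2 (0.22 log units; that floor lies within the scatter), both floors within the scatter, while a step that the two limits leave unreadable from compound 2 to compound 3 cannot be read. With an aromatic ring again on the amide-type nitrogen, no step beyond the scatter is expected in this assay, and compound 4 is expected to sit near compound 3, quite possibly again at the limit. The estimate for compound 4 is 35000 nM (range 15000 nM to 80000 nM), an expected step of an at least 1.1-fold lower number from compound 3 to compound 4 (0.05 log units; that floor lies within the scatter).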

Compound 4, half-maximal inhibitory concentration: > 40000 nM
Compound 4: only a limit was reported (the forecaster's own chance of this, stated with the estimate: 55%); middle value at least 1.1-fold (0.05 log units) away from the limit.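

In this assay benzyl, although it carries an aromatic ring of carbon only, leaves compound 4 at a limit as well, so phenyl in compound 1 remains the only group here that gives a number, and most of the series now stands at one value: the limit of > 40000 nM in this assay, at which 3 of the 4 values shown sit.

Benzyl in place of phenyl gives an at least 1.6-fold higher number from compound 1 to compound 4 (0.22 log units; that floor lies within the scatter). The steps to compound 4 from compound 2 and from compound 3 cannot be read, since both ends are limits.

As far as these compounds go, it remains open whether any group on the amide-type nitrogen gives a number clearly stronger than that of compound 1. An amine or a carboxylic acid on the phenyl ring, or a longer chain in place of benzyl, would bear on this.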